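From Nitrile to Amide on a Shared Core

This account rests on a few compounds, and the source may have more. Where it says the series, first, only, none or still open, it means among the compounds named here.

Among the three compounds measured so far, the number for compound 3 `Cc1n[nH]c(C(=O)O)c1Cc1ccc(C#N)cc1` is the lowest, though not clearly separated from all the others. In an assay on isolated protein for inhibition of 2-Hydroxyacid oxidase 2 (Homo sapiens), tested at 1 uM (on this read-out lower numbers stand for a weaker effect and higher numbers for a stronger effect at the one concentration tested), compound 3 gives 0%. Compound 1 `Cc1n[nH]c(C(=O)O)c1Cc1ccc(Oc2ccccc2)cc1` in this assay gives 10%, and the step of a number 10 percentage points lower from compound 1 to compound 3 (within the scatter), so this gap is not a real one. Compound 2 `Cc1n[nH]c(C(=O)O)c1Cc1ccc(-c2ccc(F)cc2)cc1` in this assay gives 11%, and the step of a number 11 percentage points lower from compound 2 to compound 3 (beyond the scatter).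

Compound 4 `Cc1n[nH]c(C(=O)O)c1Cc1ccc(C(N)=O)cc1` has not yet been measured. It differs from compound 3 in a single place: carbamoyl in place of cyano on an aromatic carbon.

Within the data shown here, no measured step exchanges one small group for another at this place; both steps ending at compound 3 replace a large group with cyano, and both shift the number only a little. Among the measured compounds shown here, nothing among the measured compounds points to a large move when a carbamoyl takes the place of cyano. The step of a number 5 percentage points higher from compound 3 to compound 4 (within the scatter) is therefore expected to be small, at most a few points upward from a starting point at the floor. Compound 4 is estimated to give 5% in this assay, with a likely range from 0% to 20%.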

Compound 4, a percentage reported as inhibition, at one concentration (the size of the read-out at that concentration, not a potency): 0%
Compound 4: middle estimate off by 5 percentage points, on the high side; low and high end bracket the measured number.
By their numbers in this assay, from the lowest: compounds 3, 4, 1 and 2 (each within the scatter of the next, the first and the last beyond it).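

In this assay, among these compounds, the step of no change at the digits printed from compound 3 to compound 4 (within the scatter) is the first exchange of one small group for another at this place on the ring, and the extra heavy atom and hydrogen-bond donor that carbamoyl brings leave the read-out where nitrile had it. Compound 4 also matches compound 3 against the two large groups, with a number 11 percentage points lower from compound 2 to compound 4 (beyond the scatter) and a number 10 percentage points lower from compound 1 to compound 4 (within the scatter) so only 4-fluorophenyl stands apart from the two small groups, by a modest margin, while phenoxy does not. No supporting measurement explains why the nitrile and the carbamoyl read alike.

Going by these compounds, what an amine, a carboxylic acid or a longer chain would do at this place remains open, since the two small groups here share a single read-out at the bottom of the scale. All four compounds were also read at one concentration only, so the data cannot say whether compound 3 and compound 4 would separate at a higher concentration, or whether any of these groups could give more than a modest effect on the shared core.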